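Ester versus nitrile on the side-chain of the shared core

The source may hold more compounds than are shown below. What is called first, only, known or untested is meant among the compounds shown, and "the series" means these compounds.

Among the compounds with values here, compound 2 `CC1(C)CCC[C@]2(C)[C@@H](C=O)C(/C=C/C#N)=CC[C@@H]12` stands at the lowest of the two numbers so far, though its nearest neighbour, compound 1 `CC(C)(C)OC(=O)/C=C/C1=CC[C@H]2C(C)(C)CCC[C@]2(C)[C@H]1C=O`, sits within the scatter of it. In a functional assay on MCF7 cells (Homo sapiens) for inhibition, read by MTT assay, with a stated time of 72 h (a lower number here means a stronger inhibitor of growth, a higher number a weaker inhibitor of growth), compound 2 gives 31000 nM, and in this assay compound 1 gives 32000 nM. Within the data shown here, the one measured step, a 1.0-fold lower number from compound 1 to compound 2 (0.01 log units; within the scatter), shows that exchanging the tert-butoxycarbonyl for a cyano group on the side-chain carbon leaves the number unchanged.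

Compound 3 `C#CCCCOC(=O)/C=C/C1=CC[C@H]2C(C)(C)CCC[C@]2(C)[C@H]1C=O` is not yet measured. Its change from compound 2 is ((pent-4-yn-1-yl)oxy)carbonyl in place of cyano on a double-bonded chain carbon bound to a double-bonded chain carbon. Among the measured compounds shown here, this is essentially the reverse direction of the only step seen, returning to an ester from the nitrile, with a different chain on the ester oxygen. Because a 1.0-fold lower number from compound 1 to compound 2 (0.01 log units; within the scatter) was flat, no step beyond the scatter is expected for the return to an ester, and no information on the chain itself exists in the series.

Compound 3 is therefore expected to give about 30000 nM in this assay, with a range of 12000 nM to 75000 nM. The step this implies, a 1.0-fold lower number from compound 2 to compound 3 (0.01 log units; within the scatter), is estimated to lie within the scatter.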

Compound 3, concentration for 50% growth inhibition: 30000 nM
Compound 3: the middle estimate sits on the measured number at the digits printed, and the stated range covers the measured number.
By their numbers in this assay, from the lowest: compounds 3, 2 and 1 (each within the scatter of the next).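

In this assay, the step with ((pent-4-yn-1-yl)oxy)carbonyl in place of cyano on a double-bonded chain carbon bound to a double-bonded chain carbon is a 1.0-fold lower number from compound 2 to compound 3 (0.01 log units; within the scatter), so this place now reads flat in both directions between ester and nitrile, with two different esters. The series also gains its first reading of the chain on the ester oxygen: pent-4-yn-1-yl in place of tert-butyl gives a 1.1-fold lower number from compound 1 to compound 3 (0.03 log units; within the scatter), so the terminal alkyne chain and the branched tert-butyl cannot be told apart in this assay. No measurement in hand bears on why these three side-chains read alike.

Still open, going by these compounds, is whether any group at this place can move the number beyond the scatter, for instance a carboxylic acid, an amide or an amine in place of the ester or nitrile. On these data alone, all three compounds also keep the aldehyde on the shared core, so what a primary alcohol or a carboxylic acid at that place would do to growth inhibition remains unknown.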